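Amide variation on compound 1: amino replaces 4-methylpiperazin-1-yl

A few compounds are considered here, and "the series" means these few. Any claim that something is new, unique, unknown or untested is made for them only; others in the source may bear on it.

Compound 1 `CN1CCN(C(=O)/C=C/c2ccncc2-c2ccc3ccccc3c2)CC1` was tested in an assay on a protein complex for inhibition of CDK8/Cyclin C (Homo sapiens), with a stated time of 1 h, tested at 10 uM (on this read-out higher numbers stand for more inhibition at the one concentration tested (going by the name of the read-out) and lower numbers for less inhibition), where compound 1 gives 101%. Compound 2 `O=C(/C=C/c1ccncc1-c1ccc2cccnc2c1)N1CCOCC1` gives 33% in this assay; of the two numbers, that of compound 1 is the higher, and the gap lies beyond the scatter. Compound 3 `NC(=O)/C=C/c1ccncc1-c1ccc2ccccc2c1` differs from compound 1 by amino in place of 4-methylpiperazin-1-yl on a carbonyl carbon. Within the data shown here, no measured pair shows this change on its own, so its effect is open. The step of a number 31 percentage points lower from compound 1 to compound 3 (beyond the scatter) is expected to be downward and of moderate size. For compound 3 the expected value in this assay is 70%, within the range 30% to 100%.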

Compound 3, a percentage reported as inhibition, at one concentration (the size of the read-out at that concentration, not a potency): 102%
Compound 3: middle estimate off by 32 percentage points, on the low side, and the stated range ends below it.
By their numbers in this assay, from the lowest: compound 2; then compounds 1 and 3 (each within the scatter of the next).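

In this assay, amino in place of 4-methylpiperazin-1-yl on a carbonyl carbon gives a number 1 percentage points higher from compound 1 to compound 3 (within the scatter), so the 4-methylpiperazin-1-yl ring is not required for inhibition at the one concentration tested. This single-concentration read-out does not separate compound 1 and compound 3, and it gives no comparison of potency. No available evidence explains this result.

As far as these compounds go, whether a methylamino group or a carboxylic acid on the same carbonyl carbon keeps this inhibition remains open. From the compounds shown here alone, how compound 1 and compound 3 compare across a concentration series also remains open.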